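Changing one stereocentre at level solubility

A few compounds are considered here, and "the series" means these few. Any claim that something is new, unique, unknown or untested is made for them only; others in the source may bear on it.

In a physicochemical assay for solubility, in phosphate buffer (on this read-out higher numbers stand for higher solubility and lower numbers for lower solubility), compound 1 `C[C@@H]1CN([C@H](C)CO)C(=O)c2cccc(NC(=O)c3ccncc3)c2O[C@H]1CN(C)Cc1ccc(Oc2ccccc2)cc1` gives 1000 nM. Its mirror image, compound 2 `C[C@H]1CN([C@@H](C)CO)C(=O)c2cccc(NC(=O)c3ccncc3)c2O[C@@H]1CN(C)Cc1ccc(Oc2ccccc2)cc1`, gives 1000 nM, level with compound 1. The next structure is compound 3 `C[C@@H]1CN([C@@H](C)CO)C(=O)c2cccc(NC(=O)c3ccncc3)c2O[C@@H]1CN(C)Cc1ccc(Oc2ccccc2)cc1`, and the change to it is the two compounds have the same atoms and bonds and differ only in configuration as drawn: 1 of 3 stereo elements differ; a stereocentre at a saturated ring carbon is drawn S in compound 2 and R in compound 3. For the measured compounds named here, only one measured step bears on this change, no change at the digits printed from compound 1 to compound 2 (within the scatter), and the sole fact recorded about the pair is the fact that compounds 1 and 2 differ only in the configuration as drawn. That step inverted every stereocentre, whereas the new change touches just one, so it is only an indirect guide. With so little to go on, no step beyond the scatter is expected in this assay, and no direction can be favoured. The expected step is no change at the digits printed from compound 2 to compound 3 (within the scatter). Compound 3 is estimated at 1000 nM, with an expected range of 500 nM to 2000 nM.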

Compound 3, solubility: 87000 nM
Beside the measured number, compound 3's estimate is 87-fold (1.94 log units) below it; the whole stated range lies below it.
By their numbers in this assay, from the lowest: compounds 1 and 2 (each within the scatter of the next); then compound 3.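

In this assay, inverting one stereocentre at a saturated ring carbon gives an 87-fold higher number from compound 2 to compound 3 (1.94 log units; beyond the scatter), so the read-out is sensitive to this single centre, although the full mirror-image change gave no change at the digits printed from compound 1 to compound 2 (within the scatter). The other route gives an 87-fold higher number from compound 1 to compound 3 (1.94 log units; beyond the scatter), with a saturated chain carbon and a saturated ring carbon both differing. Nothing enters or leaves in either step, so the jump in compound 3 is tied to configuration alone: the fact that compounds 2 and 3 differ only in the configuration as drawn.

The compounds shown do not tell whether inverting the chain carbon or the other ring carbon alone would produce a comparable jump, or whether this one inversion has the same effect in other configurations. As far as these compounds go, it also remains open whether the high number in compound 3 would survive a carboxylic acid or an amine added to the shared core.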